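The source may report more compounds than this note shows. Statements on the series, on what has been measured and on what is new or still open speak of the compounds shown alone.

Measured in a functional assay for inhibition, with Homo sapiens as the target; on this read-out higher numbers stand for weaker inhibition and lower numbers for stronger inhibition:
- compound 1 `CC#CCC(C)[C@H](O)/C=C/[C@H]1[C@H](O)C[C@]2(CCCCCO)C/C(=C/CCCC(=O)O)C[C@H]12`: 11000 nM
- compound 2 `CC#CCC(C)[C@H](O)/C=C/[C@H]1[C@H](O)C[C@]2(C#CCCCI)C/C(=C/CCCC(=O)O)C[C@H]12`: 200 nM
- compound 3 `CC#CCC(C)[C@H](O)/C=C/[C@H]1[C@H](O)C[C@]2(C#CCCCI)C/C(=C\CCCC(=O)O)C[C@H]12`: 5 nM

Compound 3 holds the lowest of the three numbers, and its steps to both other compounds lie beyond the scatter. Compound 4 `CC#CCC(C)[C@H](O)/C=C/[C@H]1[C@H](O)C[C@]2(C#CCCCN=[N+]=[N-])C/C(=C\CCCC(=O)O)C[C@H]12` keeps everything in compound 3 except one group: azido in place of iodo on a saturated chain carbon, three bonds along the chain from a triple-bonded carbon.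

Going by the values given here, no measured step exchanges iodo alone. The closest is a 55-fold lower number from compound 1 to compound 2 (1.74 log units; beyond the scatter), which is large but replaces 5-hydroxypentyl with 5-iodopent-1-yn-1-yl as a whole, so it cannot isolate iodo. The equally large a 40-fold lower number from compound 2 to compound 3 (1.60 log units; beyond the scatter) concerns a double bond, and compound 4 keeps that bond as drawn in compound 3. Since compound 3 already sits at 5 nM, the lowest number seen, a small change toward a higher number is expected. The expected step is an estimated 2.0-fold higher number from compound 3 to compound 4 (0.30 log units; within the scatter). For compound 4 the estimate is 10 nM, with an expected range from 2.5 nM to 50 nM.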

Compound 4, half-maximal inhibitory concentration: 20 nM
For compound 4 the middle estimate is 2.0-fold (0.30 log units) below the measured one, within the range that was stated.
By their numbers in this assay, from the lowest: compound 3; then compound 4; then compound 2; then compound 1.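

In this assay, going by these compounds alone, exchanging iodo for azido gives a 4.0-fold higher number from compound 3 to compound 4 (0.60 log units; beyond the scatter), the only measured step that changes this group alone on a saturated chain carbon, three bonds along the chain from a triple-bonded carbon. The step is modest but beyond the scatter, so the number responds to the group at this position, yet iodo is not needed for a low number: compound 4 still gives 20 nM in this series. Nothing measured here accounts for the direction or size of this step.

On these data alone, whether an amine, a nitrile or a bromo group at the same place would give a number nearer to that of compound 3 or of compound 4 remains open. So does how azido would behave on a longer chain, or with the double bond drawn as in compound 2.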